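The source may hold more compounds than are shown below. What is called first, only, known or untested is meant among the compounds shown, and "the series" means these compounds.

Measured in a functional assay on HOP-62 cells (Homo sapiens) for inhibition, read by sulforhodamine B assay; on this read-out higher numbers stand for weaker inhibition of growth and lower numbers for stronger inhibition of growth:
- compound 1 `COc1ccc(-c2ccc(-c3ccc(-c4nc5cc(C)ccc5[nH]4)cc3)cc2)cc1OC`: 2120 nM
- compound 2 `Cc1ccc2[nH]c(-c3ccc(-c4ccc(-c5ccccc5)cc4)cc3)nc2c1`: 39300 nM

Of these two, compound 2 has the higher number, at 39300 nM, so it is the weaker growth inhibitor of the pair. Compound 3 `Cc1ccc2[nH]c(-c3ccc(-c4ccc(-c5ccc(OC(F)(F)F)cc5)cc4)cc3)nc2c1` differs from it in one place: trifluoromethoxy in place of hydrogen on an aromatic carbon, para to a large group (trifluoromethoxy in place of hydrogen on an aromatic carbon). Phenyl thus becomes 4-(trifluoromethoxy)phenyl. Among the measured compounds shown here, only one measured step touches this same phenyl: a 19-fold higher number from compound 1 to compound 2 (1.27 log units; beyond the scatter), with phenyl in place of 3,4-dimethoxyphenyl. Read in reverse, that step links a substituted ring to the lower number. It is a single pair with different groups, so a smaller step in the same reverse direction is expected, towards a lower number. The estimate for compound 3 is 9000 nM, with an expected range of 2500 nM to 35000 nM. This estimate amounts to a 4.4-fold lower number from compound 2 to compound 3 (0.64 log units; beyond the scatter).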

Compound 3, concentration for 50% growth inhibition: 24200 nM
Estimate against measurement, compound 3: 2.7-fold (0.43 log units) below, within the range that was stated.
By their numbers in this assay, from the lowest: compound 1; then compounds 3 and 2 (each within the scatter of the next).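

In this assay, placing trifluoromethoxy on this aromatic carbon, para to a large group, gives a 1.6-fold lower number from compound 2 to compound 3 (0.21 log units; within the scatter). That step lies within the scatter, so the two compounds cannot be told apart, and putting this one group on the phenyl does not reproduce the lower number seen with 3,4-dimethoxyphenyl. The gap between the two substituted rings remains large, with an 11-fold higher number from compound 1 to compound 3 (1.06 log units; beyond the scatter), so what sits on this ring matters and not merely whether it is substituted, though no supporting measurement is available to explain the difference.

On these data alone, it remains open whether one methoxy group alone at this place would be enough, or whether both methoxy groups of compound 1 are needed. How an amine or a carboxylic acid would behave here is also unknown.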